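Replacing a non-aromatic ring with an aromatic one

The compounds below may be only part of what the source reports. "The series", "measured", "known", "first", "only" and "open" are said of these compounds alone.

Measured in a functional assay on C8166 cells (Homo sapiens) for cytotoxicity; on this read-out lower numbers stand for higher toxicity in this test and higher numbers for lower toxicity in this test:
Compound 1 `CSCO[C@@]1(C)CO[C@@](C)(CC(=O)OC[C@H]2O[C@@H](n3cc(C)c(=O)[nH]c3=O)C[C@@H]2O)C1`: 1000000 nM
Compound 2 `CC1=CN([C@H]2C[C@H](O)[C@@H](COC(=O)C[C@@]3(C)C[C@@](C)(O)CO3)O2)C(=O)NC1`: > 500000 nM

Compound 2 stands at > 500000 nM, and this value is a limit of the assay, not a number. Compound 1, by contrast, gives a plain number, 1000000 nM.

Compound 3 `Cc1cn([C@H]2C[C@H](O)[C@@H](COC(=O)C[C@@]3(C)C[C@@](C)(O)CO3)O2)c(=O)[nH]c1=O` departs from compound 2 in a single place, (a group of 9 heavy atoms (5 carbon, 2 nitrogen, 2 oxygen; one six-membered aromatic ring with 2 hetero atoms) in place of a group of 8 heavy atoms (5 carbon, 2 nitrogen, 1 oxygen; one six-membered non-aromatic ring with 2 hetero atoms), on a saturated ring carbon). A group with one six-membered aromatic ring with 2 hetero atoms enters where a group with one six-membered non-aromatic ring with 2 hetero atoms leaves, on a saturated ring carbon of a five-membered non-aromatic ring with 1 oxygen, next to the ring oxygen.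

For the measured compounds named here, no measured pair of compounds shows the size of such a change in this assay. The expected step that the limit leaves unreadable from compound 2 to compound 3 is none beyond the usual scatter, with no direction foreseen. Going by the values given here, this expectation leans on compound 1 at 1000000 nM, the only plain number available. The assay may well report only a limit again. For compound 3 the estimated value is 600000 nM, with an expected range of 200000 nM to 1500000 nM.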

Compound 3, half-maximal cytotoxic concentration: > 1000000 nM
Compound 3 was reported as a limit (the forecaster's own chance of this, stated with the estimate: 55%); at least 1.6-fold (0.22 log units) between middle value and limit.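

In this assay compound 3 is reported only as a limit, > 1000000 nM, and this is a limit of the assay, not a number. Hydrogen in place of (methylsulfanyl)methyl on an oxygen on a saturated carbon gives a number no lower from compound 1 to compound 3 (the limit leaves the size open). The step that brings in the six-membered aromatic ring with 2 hetero atoms, on a saturated ring carbon of a five-membered non-aromatic ring with 1 oxygen, has a limit at both ends and cannot be read, so this position shows no measurable effect of the change.

Going by these compounds, the size of the swap between the non-aromatic and the aromatic ring in this assay stays open, as does the plain number that compound 3 would give. Also open, on these data alone, is whether an amine in place of the hydroxy group on the shared core would bring the read-out within the range of the assay.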